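Methoxy to hydroxy: compound 1 and compound 4

A few compounds are considered here, and "the series" means these few. Any claim that something is new, unique, unknown or untested is made for them only; others in the source may bear on it.

Of the compounds shown here, three have been measured so far in a functional assay on OPM-2 cells (Homo sapiens) for inhibition, with a stated time of 24 h, in the presence of a further agent that is not named here (on this read-out lower numbers stand for stronger inhibition and higher numbers for weaker inhibition), on the shared core. Compound 1 `CO[C@@]1(CC(=O)N(C)C)/C=C/C[C@H](C)[C@@H](C)S(=O)(=O)NC(=O)c2ccc3c(c2)N(C[C@@H]2CC[C@H]21)C[C@@]1(CCCc2cc(Cl)ccc21)CO3` gives 41 nM and holds the lowest number of the three, which makes it the strongest inhibitor here. Compound 2 `CO[C@H]1/C=C/C[C@H](C)[C@@H](C)S(=O)(=O)NC(=O)c2ccc3c(c2)N(C[C@@H]2CC[C@H]21)C[C@@]1(CCCc2cc(Cl)ccc21)CO3` gives 240 nM and compound 3 `C[C@@H]1CC/C=C/[C@H](O)[C@@H]2CC[C@H]2CN2C[C@@]3(CCCc4cc(Cl)ccc43)COc3ccc(cc32)C(=O)NS1(=O)=O` gives 300 nM. Both of these stand beyond the scatter from compound 1, and they lie within the scatter of each other.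

Compound 4 `C[C@@H]1[C@@H](C)C/C=C/[C@@](O)(CC(=O)N(C)C)[C@@H]2CC[C@H]2CN2C[C@@]3(CCCc4cc(Cl)ccc43)COc3ccc(cc32)C(=O)NS1(=O)=O` is the next compound to be read. Its structure departs from compound 1 in one place: hydrogen in place of methyl on an oxygen on a saturated carbon. This is hydrogen in place of methyl on an oxygen on a saturated carbon, so methoxy becomes hydroxy.

Among the compounds with values here, no measured pair isolates this change, so the expectation has no direct precedent and stays anchored on compound 1 at 41 nM as the only close reference. A small move towards a higher number in this assay is expected, without certainty about its direction. The expected result is a 1.7-fold higher number from compound 1 to compound 4 (0.23 log units; within the scatter) and it is not expected to reach the numbers seen so far for the two weaker compounds. For compound 4 the estimated value is 70 nM (with an expected range of 25 nM to 200 nM) in this read-out.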

Compound 4, half-maximal inhibitory concentration: 52 nM
For compound 4 the middle estimate is 1.3-fold (0.13 log units) above the measured one; the measured number falls inside the stated range.
By their numbers in this assay, from the lowest: compounds 1 and 4 (each within the scatter of the next); then compounds 2 and 3 (each within the scatter of the next).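

In this assay the change from methoxy to hydroxy gives a 1.3-fold higher number from compound 1 to compound 4 (0.10 log units; within the scatter) and so stays within the usual scatter. Within the data shown here, this is the first step that isolates a single place, and it shows that on this oxygen on a saturated carbon, with the rest of compound 1 unchanged, methyl can give way to hydrogen without a measurable shift in this read-out. Nothing measured here bears on why the two compounds read alike.

The compounds shown leave open whether a larger group on this oxygen, such as ethyl or a longer chain, would also stay within the scatter in this assay, and whether an amine in place of the oxygen would do the same. It also remains open whether hydrogen in place of methyl on this oxygen reads the same way in compounds that lack the side chain carried by compound 1 and compound 4, as no pair shown isolates that change on such a compound.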